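Long-chain threonine amides: aryl versus dienyl acyl head

The source may report more compounds than this note shows. Statements on the series, on what has been measured and on what is new or still open speak of the compounds shown alone.

Compound 1 `CCCCCCCCCCCCNC(=O)[C@@H](NC(=O)/C=C/c1ccccc1)[C@@H](C)O` and compound 2 `C/C=C/C=C/C(=O)N[C@H](C(=O)NCCCCCCCCCCCC)[C@@H](C)O` carry the shorter alkyl amide, compound 3 `CCCCCCCCCCCCCCNC(=O)[C@@H](NC(=O)/C=C/c1ccccc1)[C@@H](C)O` and compound 4 `C/C=C/C=C/C(=O)N[C@H](C(=O)NCCCCCCCCCCCCCC)[C@@H](C)O` the longer one. In a functional assay on SiHa cells (Homo sapiens) for cytotoxicity, read by MTT assay, with a stated time of 48 h (a lower number here means a stronger inhibitor, a higher number a weaker inhibitor), compound 1 gives a limit, > 200000 nM. Compound 2 likewise gives a limit, > 200000 nM. For the measured compounds named here, compound 3 gives 35800 nM, the sole number so far. The change prop-1-en-1-yl in place of phenyl on a double-bonded chain carbon bound to a double-bonded chain carbon yields a step that the two limits leave unreadable from compound 1 to compound 2, since both ends sit at the limit of > 200000 nM in this assay, at which 2 of the 3 values shown sit. The two cores differ by ethyl in place of hydrogen on a saturated chain carbon, ten or more bonds along the chain from an amide-type nitrogen, which gives an at least 5.5-fold lower number from compound 1 to compound 3 (0.74 log units; beyond the scatter). Compound 4 carries the same change as compound 2, (prop-1-en-1-yl in place of phenyl on a double-bonded chain carbon bound to a double-bonded chain carbon), on the core of compound 3. The expected step for compound 4 is a 1.7-fold higher number from compound 3 to compound 4 (0.22 log units; within the scatter), resting on compound 3 at 35800 nM with the earlier step unreadable. Compound 4 is estimated at 60000 nM, between 20000 nM and 200000 nM.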

Compound 4, half-maximal inhibitory concentration: > 200000 nM
Compound 4 was reported as a limit (the forecaster's own chance of this, stated with the estimate: 40%); middle value at least 3.3-fold (0.52 log units) away from the limit.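

In this assay, prop-1-en-1-yl in place of phenyl on the longer-chain core gives an at least 5.5-fold higher number from compound 3 to compound 4 (0.74 log units; beyond the scatter), so on this core the change weakens the compound beyond the scatter. Compound 4 gives > 200000 nM, which is a limit and not a number. The same change on the shorter-chain core cannot be compared, and neither it nor the chain step between the two dienyl compounds can be read, because both ends of each step sit at the same value: the limit of > 200000 nM in this assay, at which 3 of the 4 values shown sit.

Going by these compounds, a longer alkyl chain on the amide remains open for both acyl heads in this assay. Also open, on these data alone, is how an amine or a carboxylic acid on the acyl head would read on the longer-chain core.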